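The source may report more compounds than this note shows. Statements on the series, on what has been measured and on what is new or still open speak of the compounds shown alone.

Measured compounds in a functional assay on a cell-free system (plasma) for inhibition of thromboxane A2 receptor (Homo sapiens), read by turbidimetry; a lower number here means a stronger inhibitor, a higher number a weaker inhibitor:
compound 1 `O=C(O)COCCCC[C@H]1[C@H](F)CC[C@@H]1NS(=O)(=O)c1ccc(F)cc1` gives 1800 nM
compound 2 `O=C(O)CC/C=C\C[C@H]1[C@H](F)CC[C@@H]1NS(=O)(=O)c1ccc(F)cc1` gives 750 nM
compound 3 `O=C(O)CCC/C=C\C[C@H]1[C@H](F)CC[C@@H]1NS(=O)(=O)c1ccc(F)cc1` gives 540 nM; 540 nM (2 entries) in two entries

Compound 2 holds the lowest of the two single numbers in this assay; its nearest neighbour is compound 1, and the step of a 2.4-fold lower number from compound 1 to compound 2 (0.38 log units; beyond the scatter) lies beyond the scatter. Compound 3 stands as a further entry with two readings rather than one number, and its difference from compound 2 lies in the chain, not in the ring.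

Compound 4 `O=C(O)CC/C=C\C[C@H]1[C@H](F)CC[C@@H]1NS(=O)(=O)c1ccc(Cl)cc1` differs from compound 2 by chloro in place of fluoro on an aromatic carbon. Among the measured compounds shown here, no measured step touches this position: the only step in hand, from compound 1 to compound 2, alters the chain bearing the acid, and compound 3 likewise varies only the chain. The aryl halide is the same in every measured compound, so nothing in the series gives a direction for this change. The expectation for compound 4 is therefore a number close to that of compound 2, with the step of a 1.2-fold lower number from compound 2 to compound 4 (0.06 log units; within the scatter) expected to stay within the scatter. Compound 4 is estimated at 650 nM, with a range from 250 nM to 1700 nM.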

Compound 4, half-maximal inhibitory concentration: 210 nM
Beside the measured number, compound 4's estimate is 3.1-fold (0.49 log units) above it; measured number below the stated range.
By their numbers in this assay, from the lowest: compound 4; then compound 2; then compound 1.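

In this assay, the halogen on the aromatic carbon para to a large group proves to be a position that responds to change, with a 3.6-fold lower number from compound 2 to compound 4 (0.55 log units; beyond the scatter) on exchanging fluoro for chloro. Until now, only the chain bearing the acid had been seen to shift the number, as in a 2.4-fold lower number from compound 1 to compound 2 (0.38 log units; beyond the scatter), and this step shows that the aryl end of the molecule also matters. No measurement at hand accounts for the step from 4-fluorophenyl to 4-chlorophenyl.

On these data alone, this reading rests on a single pair, so it remains open whether bromo, methyl or trifluoromethyl at the same place would continue the trend or reverse it. Also open, as far as these compounds go, is whether chloro gives a similar step on the chains of compound 1 and compound 3, or only on the chain of compound 2.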